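A few compounds are considered here, and "the series" means these few. Any claim that something is new, unique, unknown or untested is made for them only; others in the source may bear on it.

Measured in an ADME assay on microsomes from liver (Homo sapiens) for metabolic stability, read by LC-MS, using NADPH, with stated times of 5 min and 30 min, tested at 1 uM; on this read-out higher numbers stand for fast clearance and lower numbers for slow clearance:
- Compound 1 `O=C(Nc1ccccc1)c1cnc(NCc2c(F)ccc3c2CCO3)n2cnnc12`: 14 mL.min-1.g-1
- Compound 2 `CN(C(=O)c1ccccc1)c1cnc(NCc2c(F)ccc3c2CCO3)n2cnnc12`: > 300 mL.min-1.g-1

The second entry is a limit of the assay and not a number, so compound 2 stands on (the limit of > 300 mL.min-1.g-1 in this assay, at which 1 of the 2 values shown sits).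

Compound 3 `O=C(Nc1cnc(NCc2c(F)ccc3c2CCO3)n2cnnc12)c1ccccc1` has not yet been measured. It is compound 2 with hydrogen in place of methyl on an amide-type nitrogen.

Going by the values given here, only one measured step bears on this change: an at least 21-fold higher number from compound 1 to compound 2 (1.33 log units; beyond the scatter). It is large and beyond the scatter. It replaced phenylcarbamoyl with benzoyl(methyl)amino, and the data do not separate the methyl from the rest of that exchange. On the strength of that step, a large move towards slower clearance is expected in this assay, though its full size remains uncertain.

The estimated change is an at least 10-fold lower number from compound 2 to compound 3 (1.00 log units; beyond the scatter).

For compound 3 the expected value is 30 mL.min-1.g-1, within an estimated range of 8 mL.min-1.g-1 to 150 mL.min-1.g-1.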

Compound 3, intrinsic clearance in microsomes: 10 mL.min-1.g-1
The estimate for compound 3 lay 3.0-fold (0.48 log units) above the measured number; the measured number falls inside the stated range.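

The new compound separates the methyl from the rest of the earlier exchange: in this assay, hydrogen in place of methyl on the amide-type nitrogen alone gives an at least 30-fold lower number from compound 2 to compound 3 (1.47 log units; beyond the scatter). Benzamido in place of phenylcarbamoyl gives a 1.4-fold lower number from compound 1 to compound 3 (0.15 log units; within the scatter), which lies within the scatter, so this read-out does not tell these two amide arrangements apart when the nitrogen carries hydrogen. The full size of the methyl step stays unknown, since the number for compound 2 is a limit and not a measured value: the limit of > 300 mL.min-1.g-1 in this assay, at which 1 of the 3 values shown sits.

The compounds shown leave open whether an ethyl group or a longer chain on that nitrogen would behave as methyl does. They also leave open how an amine or a carboxylic acid on the phenyl of the benzamido group would read in this assay.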